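The source may report more compounds than this note shows. Statements on the series, on what has been measured and on what is new or still open speak of the compounds shown alone.

Measured in a functional assay on HT-1080 cells (Homo sapiens) for cytotoxicity, read by MTT assay, with a stated time of 72 h; on this read-out higher numbers stand for weaker inhibition and lower numbers for stronger inhibition:
Compound 1 `COc1ccc(/C=C2\CCC/C(=C\c3cccc(OC)c3OC)C2=O)cc1OC`: 6400 nM
Compound 2 `COc1ccc(/C=C2\CCC/C(=C\c3cccc(Cl)c3)C2=O)cc1OC`: 4900 nM
Compound 3 `COc1ccc(/C=C2\CCC/C(=C\c3cccc(Br)c3)C2=O)cc1OC`: 5200 nM

In this assay the three compounds form a tight group. Compound 3, at 5200 nM, lies within the usual scatter of both compound 2 and compound 1, so it cannot be told apart from either on these numbers.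

The next compound to be tested is compound 4 `COc1cccc(/C=C2\CCC/C(=C\c3ccc(OC)c(OC)c3)C2=O)c1`. It differs from compound 3 at a single place, methoxy in place of bromo on an aromatic carbon, meta to a large group, so that 3-bromophenyl becomes 3-methoxyphenyl.

Among the compounds with values here, no measured step makes this exact exchange, so the evidence is indirect. The closest measured step is the exchange of one halogen for another, a 1.1-fold higher number from compound 2 to compound 3 (0.03 log units; within the scatter). Compound 1 also bears on the question, since it carries methoxy groups on the corresponding ring and still gives 6400 nM, within the scatter of compound 3. Nothing in this small set therefore points to a real shift in either direction.

The expected change is a 1.1-fold higher number from compound 3 to compound 4 (0.02 log units; within the scatter), which would be none beyond the scatter. For compound 4 the estimated value is 5500 nM, with an expected range from 2500 nM to 11000 nM.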

Compound 4, half-maximal inhibitory concentration: 4600 nM
The estimate for compound 4 lay 1.2-fold (0.08 log units) above the measured number; the measured number falls inside the stated range.
By their numbers in this assay, from the lowest: compounds 4, 2, 3 and 1 (each within the scatter of the next).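

In this assay, within the data shown here, the 3-bromophenyl to 3-methoxyphenyl exchange on this aromatic carbon, meta to a large group, is read directly for the first time (a 1.1-fold lower number from compound 3 to compound 4 (0.05 log units; within the scatter)), and the exchange from chloro to methoxy at the same place also stays within the scatter (a 1.1-fold lower number from compound 2 to compound 4 (0.03 log units; within the scatter)), so methoxy cannot be told apart from either halogen here. The third step adds that hydrogen in place of methoxy on an aromatic carbon of this ring also gives no shift beyond the scatter (a 1.4-fold lower number from compound 1 to compound 4 (0.14 log units; within the scatter)), so none of the exchanges read so far on this ring separates the compounds in this assay. No measurement shown here accounts for this flat result.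

All four compounds keep the same shared core and the same dimethoxy-substituted ring on its other side, so only chloro, bromo and methoxy have been seen at this place. Going by these compounds, whether an amine, a carboxylic acid or a longer chain such as butoxy at this place, or any change to the other ring, would move the number beyond the scatter remains open.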